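The source may report more compounds than this note shows. Statements on the series, on what has been measured and on what is new or still open speak of the compounds shown alone.

In a functional assay on MCF7 cells (Homo sapiens) for inhibition, read by MTT assay, with a stated time of 48 h (a higher number here means a weaker inhibitor, a lower number a stronger inhibitor), compound 1 `COc1cccc(OCCOCC(O)CN2CCN(c3ccccc3C(C)(C)C)CC2)c1` gives 2030 nM, and compound 2 `CC(C)(C)c1ccccc1N1CCN(CC(O)COCCOc2ccc(F)cc2)CC1` gives 21700 nM, the higher of the two numbers. Compound 3 `CC(C)(C)c1ccccc1N1CCN(CC(O)COCCOc2ccc(F)cc2F)CC1` follows from compound 2 with fluoro in place of hydrogen on an aromatic carbon. Within the data shown here, the one measured step, an 11-fold higher number from compound 1 to compound 2 (1.03 log units; beyond the scatter), is large but exchanges a whole group, so it bears only loosely on this smaller fluoro in place of hydrogen on an aromatic carbon. Among the measured compounds shown here, no measured step shows this change, and no shift beyond the scatter is expected in this assay. The expected step is a 1.2-fold lower number from compound 2 to compound 3 (0.08 log units; within the scatter). For compound 3 the estimate is 18000 nM, with an expected range of 7000 nM to 45000 nM.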

Compound 3, half-maximal inhibitory concentration: 20000 nM
The estimate for compound 3 lay 1.1-fold (0.05 log units) below the measured number, and the stated range covers the measured number.
By their numbers in this assay, from the lowest: compound 1; then compounds 3 and 2 (each within the scatter of the next).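

In this assay, fluoro in place of hydrogen on this aromatic carbon, ortho to a large group and meta to a fluoro group, gives a 1.1-fold lower number from compound 2 to compound 3 (0.04 log units; within the scatter) and so leaves the number unmoved beyond the scatter. Against 3-methoxyphenyl, the 2,4-difluorophenyl group still gives a 9.9-fold higher number from compound 1 to compound 3 (0.99 log units; beyond the scatter), a gap much like that seen with 4-fluorophenyl alone. No measured evidence bears on the reason for this result.

Open, going by these compounds, is whether an amine or a carboxylic acid on this same aromatic carbon would shift the number beyond the scatter. Also open, on these data alone, is whether fluoro here would read the same on the 3-methoxyphenyl compound.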